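Swapping a Naphthyl for a Fluorophenyl on a Shared Core

The source may hold more compounds than are shown below. What is called first, only, known or untested is meant among the compounds shown, and "the series" means these compounds.

Three compounds have so far been measured in a functional assay on MCF7 cells (Homo sapiens) for inhibition, read by sulforhodamine B assay, with a stated time of 48 h, tested at 10 uM; a higher number here means more inhibition at the concentration tested (going by the name of the read-out), a lower number less inhibition:
compound 1, `Brc1cn2ccnc2c(-c2ccc3ncn(C4CCCCC4)c3c2)n1`, gives 47.6%;
compound 2, `COc1ccc(-c2cn3ccnc3c(-c3ccc4ncn(C5CCCCC5)c4c3)n2)cc1`, gives 80.2%;
compound 3, `c1ccc2c(-c3cn4ccnc4c(-c4ccc5ncn(C6CCCCC6)c5c4)n3)cccc2c1`, gives 13%.

Compound 3 stands lowest of the three numbers. Its nearest neighbour is compound 1, reached by a number 34.6 percentage points lower from compound 1 to compound 3 (beyond the scatter), and its furthest is compound 2, reached by a number 67.2 percentage points lower from compound 2 to compound 3 (beyond the scatter). Both steps lie beyond the scatter, so the number for compound 3 is clearly the lowest of the measured set in this assay.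

The next compound, compound 4, `Fc1ccccc1-c1cn2ccnc2c(-c2ccc3ncn(C4CCCCC4)c3c2)n1`, is made from compound 3 by one change: 2-fluorophenyl in place of naphthalen-1-yl on an aromatic carbon.

For the measured compounds named here, two measured steps bear on this. The step of a number 67.2 percentage points lower from compound 2 to compound 3 (beyond the scatter) shows that replacing one aromatic group with a naphthalen-1-yl at this position cost a great deal of inhibition, and a number 34.6 percentage points lower from compound 1 to compound 3 (beyond the scatter) shows the naphthalen-1-yl sitting well below even a bromo. Reversing that direction, from naphthalen-1-yl back to a single six-membered ring, is therefore expected to raise inhibition by a large step, a number 42 percentage points higher from compound 3 to compound 4 (beyond the scatter). Going by the values given here, how far it climbs is uncertain, since no measured compound carries a 2-fluorophenyl; compound 2 with its 4-methoxyphenyl is the closest guide. Compound 4 is thus estimated at 55%, within a range of 25% to 85% in this assay.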

Compound 4, a percentage reported as inhibition, at one concentration (the size of the read-out at that concentration, not a potency): 11.2%
Compound 4: the middle estimate sits 43.8 percentage points above what was measured; measured number below the stated range.
By their numbers in this assay, from the lowest: compounds 4 and 3 (each within the scatter of the next); then compound 1; then compound 2.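

In this assay, going from the two fused carbon rings of naphthalen-1-yl to the single ring of 2-fluorophenyl does not bring inhibition back: the change is a number 1.8 percentage points lower from compound 3 to compound 4 (within the scatter), so the two groups cannot be told apart at this position. Having a single aromatic ring here is therefore not enough on its own, as the comparison with the other single-ring compound gives a number 69 percentage points lower from compound 2 to compound 4 (beyond the scatter), which shows that what the ring carries matters a great deal. The 2-fluorophenyl group also falls well short of a plain bromo, with a number 36.4 percentage points lower from compound 1 to compound 4 (beyond the scatter), so among the four compounds only the 4-methoxyphenyl group of compound 2 lifts inhibition above the bromo of compound 1.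

Nothing measured here explains why these two single-ring groups lie so far apart. The 4-methoxyphenyl and 2-fluorophenyl rings differ both in the group they carry and in where they carry it, so these compounds leave open which of the two matters, and how a phenyl ring bearing a dimethylamino group or a carboxylic acid would behave at this position.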